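A few compounds are considered here, and "the series" means these few. Any claim that something is new, unique, unknown or untested is made for them only; others in the source may bear on it.

Working notes on the cyclopropane amide series.

The series is read in a functional assay on the whole organism (strain albino Sprague-Dawley) with Rattus norvegicus as the target, in the maximal electroshock model; a higher number here means that more compound is needed for the effect, a lower number that less compound is needed. Compound 1, `CNC(=O)C1C(C)(C)C1(C)C`, carries the amide as a secondary amide with a methyl on nitrogen; in this assay compound 1 gives 82 mg/kg. Compound 2, `CC1(C)C(C)(C)C1(F)C(N)=O`, carries a primary amide and a fluoro on the ring carbon that bears it. For compound 2 this assay reports only a limit, > 100 mg/kg, and no number. Compound 2 therefore stands at the top edge of the shown numbers, as the limit of > 100 mg/kg in this assay, at which 1 of the 2 values shown sits, records, while compound 1 sits inside the measurable range.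

The step under consideration goes from compound 2 to compound 3, `CC1(C)C(C(N)=O)C1(C)C`. The change is hydrogen in place of fluoro on a saturated ring carbon of a three-membered non-aromatic ring of carbon only, with the primary amide kept. Within the data shown here, no measured step of this kind exists, so the size can only be expected. Compound 3 is expected to move into the measurable range, with a step from the limit estimated as an at least 1.6-fold lower number from compound 2 to compound 3 (0.22 log units; that floor lies within the scatter). The dose for half-maximal effect of compound 3 is estimated at 60 mg/kg, with a range from 25 mg/kg to 150 mg/kg.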

Compound 3, dose for half-maximal effect: > 250 mg/kg
Compound 3 gave a limit, no number (the forecaster's own chance of this, stated with the estimate: 30%); middle value at least 4.1-fold (0.61 log units) from the limit.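

Replacing fluoro with hydrogen on the saturated ring carbon does not bring the primary amide into the measurable range in this assay, and with limits on both sides the step between compound 2 and compound 3 cannot be read. The new information lies at the amide nitrogen, where hydrogen in place of methyl on an amide-type nitrogen gives an at least 3.0-fold higher number from compound 1 to compound 3 (0.48 log units; beyond the scatter), so among the compounds without the ring fluoro, the methyl on nitrogen separates a measured dose from a limit. Compound 3 therefore adds a second limit to the series, not a number: the limit of > 250 mg/kg in this assay, at which 1 of the 3 values shown sits.

The compounds shown leave open what the fluoro does when the methyl on nitrogen is kept, and how far the two primary amides lie from each other, as each is held only as a limit. They also leave open whether a longer chain on the amide nitrogen, such as an ethyl or propyl group, would give a lower or a higher number than compound 1 gives at 82 mg/kg.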